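This account rests on a few compounds, and the source may have more. Where it says the series, first, only, none or still open, it means among the compounds named here.

Measured so far in an ADME assay on BJ cells (Homo sapiens) for cytotoxicity, with a stated time of 72 h; on this read-out lower numbers stand for an effect already at smaller amounts and higher numbers for an effect only at larger amounts of compound:
- Compound 1 `C=C[C@@](C)(/C=C/c1ccc(OCc2ccccc2)cc1)CCC=C(C)C`: > 36600 nM, a limit
- Compound 2 `C=C[C@@](C)(/C=C/c1ccc(Nc2ccc(OC)c(F)c2)cc1)CCC=C(C)C`: > 36600 nM, a limit
- Compound 3 `C=C[C@@](C)(/C=C/c1ccc(Nc2ccc(F)cc2)cc1)CCC=C(C)C`: > 36600 nM, a limit

Compound 3 has no number on this read-out, only the limit > 36600 nM. The three compounds share (the limit of > 36600 nM in this assay, at which 3 of the 3 values shown sit).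

Compound 4 `C=C[C@@](C)(/C=C/c1ccc(Nc2ccc(F)c(F)c2)cc1)CCC=C(C)C` follows from compound 3 by putting fluoro in place of hydrogen on an aromatic carbon, ortho to a fluoro group and meta to a large group: fluoro in place of hydrogen on an aromatic carbon.

Going by the values given here, two measured steps bear on this change, and neither has a readable size: a step that the two limits leave unreadable from compound 2 to compound 3, and a step that the two limits leave unreadable from compound 1 to compound 3. The first is the closer, since it also changes the aryl group on the nitrogen. Neither gives a size to carry over, and neither gives a direction. The expectation is therefore no step beyond the scatter in this assay, with compound 4 most likely reported as a limit too. The expected step is a number no higher from compound 3 to compound 4 (the limit leaves the size open). Compound 4 is estimated at 36600 nM, with an expected range of 15000 nM to 60000 nM.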

Compound 4, half-maximal effective concentration: > 36600 nM
Compound 4: only a limit was reported; the forecaster's own chance of this, stated with the estimate: 85%; the middle value lies on the limit itself.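

In this assay compound 4 gives only the limit > 36600 nM and no number, so its steps from compound 1, compound 2 and compound 3 cannot be read. The compounds shown leave open whether any of these changes alters cytotoxicity at all, since all of them share one ceiling: the limit of > 36600 nM in this assay, at which 4 of the 4 values shown sit.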